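A few compounds are considered here, and "the series" means these few. Any claim that something is new, unique, unknown or untested is made for them only; others in the source may bear on it.

Of the compounds shown here, three that share one core have been tested in an assay on adrenal medulla for inhibition of Vasopressin V2 receptor (Rattus norvegicus), read by radioligand binding; a lower number here means a stronger inhibitor, a higher number a weaker inhibitor. Compound 1 `O=C(Nc1ccc(C(=O)N2CCCN(CCN3CCCC3)c3sccc32)cc1)c1ccccc1-c1ccccc1` gives 10 nM. Compound 3 `CN(C)CCN1CCCN(C(=O)c2ccc(NC(=O)c3ccccc3-c3ccccc3)cc2)c2ccsc21` gives 20 nM. Compound 2 `CN1CCCN(C(=O)CCCOc2cc(C(=O)N3CCCCc4sccc43)ccc2NC(=O)c2ccccc2-c2ccccc2)CC1` gives 3 nM, the lowest of the three numbers; its gap to compound 1 and its gap to compound 3 both lie beyond the scatter, so on these numbers compound 2 is the strongest inhibitor of the three. Among the compounds with values here, only one pair of measured compounds differs in a single place: a 2.0-fold higher number from compound 1 to compound 3 (0.30 log units; within the scatter). That exchange of one nitrogen-bearing group for another left the number essentially where it was.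

Compound 4 `CN(C)C1CCN(C(=O)CCCOc2cc(C(=O)N3CCCCc4sccc43)ccc2NC(=O)c2ccccc2-c2ccccc2)CC1` has not yet been measured. It differs from compound 2 in one place: 4-(dimethylamino)piperidin-1-yl in place of 4-methyl-1,4-diazepan-1-yl on a carbonyl carbon. Here too one nitrogen-bearing ring is exchanged for another, this time on a carbonyl carbon at the end of the chain rather than in the part the measured compounds share. Within the data shown here, the single measured step that resembles such an exchange, from compound 1 to compound 3, stayed within the scatter, so no step beyond the scatter is expected in this assay, in either direction. Compound 4 is therefore expected to give about 4 nM, between 1.5 nM and 12 nM, an expected change of a 1.3-fold higher number from compound 2 to compound 4 (0.12 log units; within the scatter).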

Compound 4, half-maximal inhibitory concentration: 3 nM
Estimate against measurement, compound 4: 1.3-fold (0.12 log units) above; low and high end bracket the measured number.
By their numbers in this assay, from the lowest: compounds 2 and 4 (each within the scatter of the next); then compounds 1 and 3 (each within the scatter of the next).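

In this assay, the exchange reads as no change at the digits printed from compound 2 to compound 4 (within the scatter), so the two compounds cannot be told apart even though the group on this carbonyl carbon is rebuilt: a seven-membered ring with 2 hetero atoms gives way to a six-membered ring with 1 hetero atom, the heavy atoms go from 8 to 9, and one of the two nitrogens now stands outside the ring. Within the data shown here, the earlier step, a 2.0-fold higher number from compound 1 to compound 3 (0.30 log units; within the scatter), concerned a different place, a saturated chain carbon, so this is the first reading at the carbonyl end of the chain, and it too stays within the scatter. Nothing at hand explains why the number holds across this exchange.

From the compounds shown here alone, both groups seen at this carbonyl carbon carry two nitrogens, so it remains open whether piperidin-1-yl or morpholin-4-yl, with a single nitrogen or none beyond the ring nitrogen's amide link, or a carboxylic acid in place of the amide, would read the same. Going by these compounds, a longer or shorter chain leading to this carbonyl is also open.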